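The source may hold more compounds than are shown below. What is called first, only, known or untested is meant among the compounds shown, and "the series" means these compounds.

In a functional assay on MCF7 cells (Homo sapiens) for cytotoxicity, read by MTT assay, with a stated time of 72 h (on this read-out higher numbers stand for weaker inhibition and lower numbers for stronger inhibition), compound 1 `CN1[C@@H]2c3[nH]c4ccccc4c3C[C@H]1[C@H](C#N)N1[C@@H](CN3C(=O)c4ccccc4C3=O)c3[nH]c4ccccc4c3C[C@@H]21` gives 610 nM. Compound 2 `CN1[C@@H]2c3[nH]c4ccccc4c3C[C@H]1[C@H](C#N)N1[C@@H](CNC(=O)c3cccc4c3CCCC4)c3[nH]c4ccccc4c3C[C@@H]21` gives 4470 nM, and compound 3 `CN1[C@@H]2c3[nH]c4ccccc4c3C[C@H]1[C@H](C#N)N1[C@@H](CNC(=O)c3ccc4ccccc4c3)c3[nH]c4ccccc4c3C[C@@H]21` gives 4650 nM, the highest number shown, though its gap to compound 2 lies within the scatter. Compound 4 `COc1ccc(/C=C/C(=O)NC[C@H]2c3[nH]c4ccccc4c3C[C@H]3[C@H]4c5[nH]c6ccccc6c5C[C@@H]([C@H](C#N)N23)N4C)cc1` carries 2-(4-methoxyphenyl)ethenyl in place of naphthalen-2-yl on a carbonyl carbon. Among the measured compounds shown here, no measured pair covers this particular exchange. The only step that swapped the group on the carbonyl carbon, a 1.0-fold higher number from compound 2 to compound 3 (0.02 log units; within the scatter), traded one ring group for another and stayed within the scatter, so a group swap at this position has so far shown little effect. For compound 4 the expected step is a 1.0-fold lower number from compound 3 to compound 4 (0.01 log units; within the scatter), none beyond the scatter. Compound 4 is therefore estimated at 4500 nM, with a range from 1500 nM to 13000 nM.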

Compound 4, half-maximal inhibitory concentration: 4220 nM
Compound 4: middle estimate off by 1.1-fold (0.03 log units), on the high side, within the range that was stated.
By their numbers in this assay, from the lowest: compound 1; then compounds 4, 2 and 3 (each within the scatter of the next).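

Among the compounds shown here, replacing naphthalen-2-yl with 2-(4-methoxyphenyl)ethenyl, which brings a double bond outside aromatic rings and a hydrogen-bond acceptor but only one aromatic ring, gives a 1.1-fold lower number from compound 3 to compound 4 (0.04 log units; within the scatter) in this assay. Measured against the 1,2,3,4-tetrahydronaphthalen-5-yl group, the same new group gives a 1.1-fold lower number from compound 2 to compound 4 (0.02 log units; within the scatter), so all three groups on this carbonyl carbon now read alike within the scatter. Nothing measured here explains this closeness. As far as these compounds go, whether a group carrying an amine or a carboxylic acid at this carbonyl carbon would move the number beyond the scatter stays open.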